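The source may hold more compounds than are shown below. What is called first, only, known or untested is meant among the compounds shown, and "the series" means these compounds.

Compound 3 `CCOC(=O)CCCCCOc1cccc(CN(C(=O)c2ccc(-c3cccc(N(C)C)c3)cc2)C(C)C)c1` stands at a limit: in an ADME assay on BJ cells (Homo sapiens) for cytotoxicity, read by CellTiter-Glo and resazurin assay, with a stated time of 72 h (a lower number here means that less compound is needed, a higher number that more compound is needed for the effect), compound 3 gives > 26000 nM. Compound 2 `CCOC(=O)CCCCCOc1cccc(CN(C(=O)c2ccccc2)C(C)C)c1` rests at the same limit, giving > 26000 nM in this assay. The step that the two limits leave unreadable from compound 2 to compound 3 is therefore unreadable because both values rest on (the limit of > 26000 nM in this assay, at which 2 of the 3 values shown sit). Compound 1 `CC(C)N(Cc1cccc(OCCCCCC(=O)O)c1)C(=O)c1ccc(-c2cccc3ccccc23)cc1`, carrying the free acid chain and the naphthalen-1-yl group, gives < 1.3 nM in this assay, a limit in the other direction, (the limit of < 1.3 nM in this assay, at which 1 of the 3 values shown sits). Compound 4 `CCOC(=O)CCCCCOc1cccc(CN(C(=O)c2ccc(-c3cccc4ccccc34)cc2)C(C)C)c1` differs from compound 3 by naphthalen-1-yl in place of 3-(dimethylamino)phenyl on an aromatic carbon. No measured step covers this change; compound 1 and compound 4 differ only at the chain end, and no step is shown for that. The step of an at least 52-fold lower number from compound 3 to compound 4 (1.71 log units; beyond the scatter) is expected toward lower values, with wide uncertainty. Compound 4 is estimated at 500 nM, in the range 10 nM to 26000 nM.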

Compound 4, half-maximal effective concentration: > 26000 nM
Compound 4: no number, only a limit; the forecaster's own chance of this, stated with the estimate: 30%; at least 52-fold (1.71 log units) between middle value and limit.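

In this assay compound 4 gives > 26000 nM, a limit, so with the ethyl ester in place, naphthalen-1-yl para to a large group leaves the compound at the same limit as 3-(dimethylamino)phenyl; the steps from compound 2 and compound 3 cannot be read. The chain end, not the aromatic group, is now the change that separates the values: ethyl ester for free acid gives an at least 20000-fold higher number from compound 1 to compound 4 (4.30 log units; beyond the scatter).

Compound 1 is the only free acid shown, so whether the low limit needs naphthalen-1-yl as well stays open. On these data alone, how a shorter chain or an amine at the chain end would read also stays open.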